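Replacing a pyrrole ketone by a fluorophenyl ketone

The source may report more compounds than this note shows. Statements on the series, on what has been measured and on what is new or still open speak of the compounds shown alone.

Measured so far:
compound 1 `Cn1cccc1C(=O)/C=C/c1ccc2c(c1)B(O)OC2` > 100000 nM
compound 2 `CCc1ccc(C(=O)/C=C/c2ccc3c(c2)B(O)OC3)cc1` 20600 nM
compound 3 `O=C(/C=C/c1ccc2c(c1)B(O)OC2)c1ccc(OCc2ccccc2)cc1` > 100000 nM

All three share the same core and differ only in the aryl group attached to the carbonyl carbon. In a toxicity assay on WI-38 cells (Homo sapiens) for cytotoxicity, read by MTT assay, with a stated time of 48 h (a lower number here means a stronger inhibitor, a higher number a weaker inhibitor), compound 1 gives > 100000 nM, which is a limit of the assay and not a number. Compound 2 gives 20600 nM in this assay. Compound 3 gives > 100000 nM in this assay, again a limit. Among the compounds with values here, the one step between two measured compounds is an at least 4.8-fold higher number from compound 2 to compound 3 (0.68 log units; beyond the scatter), and the limit of > 100000 nM in this assay, at which 2 of the 3 values shown sit, shows how often the values end at the edge of what the assay can report.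

Compound 4 `O=C(/C=C/c1ccc2c(c1)B(O)OC2)c1ccccc1F` is the unmeasured compound, and it differs from compound 1 by 2-fluorophenyl in place of 1-methyl-1H-pyrrol-2-yl on a carbonyl carbon. Within the data shown here, none of the measured steps involves this change, so the expectation rests on the spread of the three values. Compound 2, with a plain six-membered carbon ring bearing a small alkyl group, gave a number inside the measurable range, while compound 1 and compound 3 did not. Compound 4 is therefore expected to land between those outcomes, at 40000 nM with a range from 12000 nM to 150000 nM. That estimate implies an expected step of an at least 2.5-fold lower number from compound 1 to compound 4 (0.39 log units; beyond the scatter), with a real chance that this assay again reports only a limit.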

Compound 4, half-maximal inhibitory concentration: 23600 nM
Compound 4: middle estimate off by 1.7-fold (0.23 log units), on the high side; the range from low to high includes it.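

Exchanging 1-methyl-1H-pyrrol-2-yl for 2-fluorophenyl on the carbonyl carbon gives, in this assay, an at least 4.2-fold lower number from compound 1 to compound 4 (0.62 log units; beyond the scatter). The earlier step changed only a group carried on a phenyl ring, whereas this one shows that replacing the ring attached to the carbonyl carbon can also move the result beyond the usual scatter. Compound 1 gives > 100000 nM, which is a limit of the assay and not a number, so this step has a lower bound but no exact size, and such limits remain common in this small set: the limit of > 100000 nM in this assay, at which 2 of the 4 values shown sit.

The compounds shown leave open whether the change follows from the switch to a six-membered carbon ring or from the fluorine it carries, a distinction that a plain phenyl group on the carbonyl carbon could help to settle. They also leave open how this assay would respond to a ring carrying an amine or a carboxylic acid, or to a chlorine in place of the fluorine in 2-fluorophenyl.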